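The compounds below may be only part of what the source reports. "The series", "measured", "known", "first", "only" and "open" are said of these compounds alone.

Three compounds share the same core, a sugar-linked adenine unit. In an assay for inhibition of tRNA (cytosine(38)-C(5))-methyltransferase (Homo sapiens), with a stated time of 5 min, tested at 100 uM (a lower number here means less inhibition, a higher number more inhibition at the concentration tested (going by the name of the read-out)), compound 1 `NCCCSC[C@H]1O[C@@H](n2cnc3c(N)ncnc32)[C@H](O)[C@@H]1O` gives no result reported. Compound 2 `Nc1ncnc2c1ncn2[C@@H]1O[C@H](CN(CC[C@H](N)C(=O)O)CC2CCCC2)[C@@H](O)[C@H]1O` carries the only number shown: in this assay compound 2 gives 24.5%, a modest degree of inhibition at the concentration tested. Compound 3 `Nc1ncnc2c1ncn2[C@@H]1O[C@H](CN(CC[C@H](N)C(=O)O)Cc2ccccc2)[C@@H](O)[C@H]1O` differs from compound 2 in one place (phenyl in place of cyclopentyl on a saturated chain carbon bound to an amine nitrogen). Among the compounds with values here, no measured step between related compounds is available to guide the estimate. The expected step is a number 0.5 percentage points higher from compound 2 to compound 3 (within the scatter), which is meant as no change beyond the usual scatter. Compound 3 is therefore estimated to give 25%, with a range from 10% to 40%.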

Compound 3, a percentage reported as inhibition, at one concentration (the size of the read-out at that concentration, not a potency): 56.8%
Beside the measured number, compound 3's estimate is 31.8 percentage points below it, and the stated range ends below it.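

Phenyl in place of cyclopentyl on a saturated chain carbon bound to an amine nitrogen gives, in this assay, a number 32.3 percentage points higher from compound 2 to compound 3 (beyond the scatter) and so this position is sensitive to which ring it carries. A six-membered aromatic ring and a five-membered non-aromatic ring of carbon are not interchangeable here. No measurement shown explains the difference. Going by these compounds, it remains open whether the aromatic ring or the extra ring carbon matters, as cyclohexyl would help to show. Also open, on these data alone, is how phenethyl in place of benzyl, or a methoxy group on the phenyl, would read out.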